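A few compounds are considered here, and "the series" means these few. Any claim that something is new, unique, unknown or untested is made for them only; others in the source may bear on it.

Among the three measured compounds, compound 3 `COc1ccc(C(=O)/C=C/c2cc(-c3cc(OC)c(OC)c(OC)c3)n[nH]2)cc1` gives the lowest number in a functional assay on MCF7 cells (Homo sapiens) for inhibition, read by MTT assay, with a stated time of 48 h (on this read-out lower numbers stand for stronger inhibition and higher numbers for weaker inhibition), at 810 nM. Compound 1 `COc1cc(-c2cc(/C=C/C(=O)c3ccccc3)[nH]n2)cc(OC)c1OC` gives 2100 nM in this assay, and compound 2 `COc1cc(-c2cc(/C=C/C(C)=O)[nH]n2)cc(OC)c1OC` gives 20100 nM. The untested compound 4 `COc1cc(-c2cc(/C=C/C(=O)c3ccc(F)c(F)c3)[nH]n2)cc(OC)c1OC` differs from compound 3 by 3,4-difluorophenyl in place of 4-methoxyphenyl on a carbonyl carbon. Among the measured compounds shown here, no measured step swaps one aryl group for another; the nearest guide is a 2.6-fold lower number from compound 1 to compound 3 (0.41 log units; beyond the scatter), which shows the gain brought by the methoxy group that compound 4 loses. The steps of a 9.6-fold higher number from compound 1 to compound 2 (0.98 log units; beyond the scatter) and a 25-fold lower number from compound 2 to compound 3 (1.39 log units; beyond the scatter) bear only on methyl against aryl. Compound 4 is therefore expected to sit between compound 1 and compound 3, with an estimated step of a 1.9-fold higher number from compound 3 to compound 4 (0.27 log units; within the scatter). Compound 4 is estimated at 1500 nM, between 500 nM and 4500 nM.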

Compound 4, half-maximal inhibitory concentration: 2500 nM
The estimate for compound 4 lay 1.7-fold (0.22 log units) below the measured number; measured number inside the range.
By their numbers in this assay, from the lowest: compound 3; then compounds 1 and 4 (each within the scatter of the next); then compound 2.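

In this assay, the change to 3,4-difluorophenyl on the carbonyl carbon does not keep the lower number of the 4-methoxyphenyl compound (a 3.1-fold higher number from compound 3 to compound 4 (0.49 log units; beyond the scatter)), and the difluorinated ring stays within the scatter of plain phenyl (a 1.2-fold higher number from compound 1 to compound 4 (0.08 log units; within the scatter)). It still gives a lower number than methyl at this place (an 8.0-fold lower number from compound 2 to compound 4 (0.91 log units; beyond the scatter)), so this second substituted aryl group also keeps the advantage over methyl. Nothing at hand explains these differences.

On these data alone, whether a 4-aminophenyl or 4-hydroxyphenyl group would match or pass the 4-methoxyphenyl group remains open. So does the separate contribution of each fluorine.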